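The source may report more compounds than this note shows. Statements on the series, on what has been measured and on what is new or still open speak of the compounds shown alone.

In a functional assay on SGC-7901 cells (Homo sapiens) for antiproliferative activity, read by MTT assay, with a stated time of 72 h (a lower number here means a stronger inhibitor, a higher number a weaker inhibitor), compound 1 `COc1ccccc1-c1ccc2ncn(-c3cc(OC)c(OC)c(OC)c3)c2c1`, with a 2-methoxyphenyl group, gives 5050 nM, and compound 2 `COc1cc(-n2cnc3ccc(-c4cccc(Cl)c4)cc32)cc(OC)c1OC`, with a 3-chlorophenyl group, gives 1490 nM. Compound 3 `COc1cc(-n2cnc3ccc(-c4ccc(O)cc4)cc32)cc(OC)c1OC`, with a 4-hydroxyphenyl group, gives > 10000 nM, which is a limit of the assay and not a number. Its standing is therefore known only as the limit of > 10000 nM in this assay, at which 1 of the 3 values shown sits.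

Compound 4 `COc1cc(-n2cnc3ccc(-c4ccc(F)cc4)cc32)cc(OC)c1OC` differs from compound 3 in one place, with fluoro in place of hydroxy on an aromatic carbon, para to a large group: fluoro in place of hydroxy on an aromatic carbon.

Going by the values given here, two measured steps bear on this change, since both bring in the 4-hydroxyphenyl group. One is an at least 6.7-fold higher number from compound 2 to compound 3 (0.82 log units; beyond the scatter), which is beyond the scatter. The other is an at least 1.9-fold higher number from compound 1 to compound 3 (0.29 log units; that floor lies within the scatter), and its floor lies within the scatter, so compound 1 gives weaker support. Neither step involves a fluoro group, and the two non-hydroxy groups themselves differ, as a 3.4-fold lower number from compound 1 to compound 2 (0.53 log units; beyond the scatter) shows. Removing the hydroxy group should therefore take compound 4 towards the values of compound 1 and compound 2, with a lower number than the limit of compound 3, though the size is uncertain.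

In this assay the estimated step is an at least 4.0-fold lower number from compound 3 to compound 4 (0.60 log units; beyond the scatter). The expected value for compound 4 is 2500 nM, with an estimated range of 800 nM to 8000 nM.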

Compound 4, half-maximal inhibitory concentration: 3500 nM
Estimate against measurement, compound 4: 1.4-fold (0.15 log units) below; low and high end bracket the measured number.
By their numbers in this assay, from the lowest: compound 2; then compounds 4 and 1 (each within the scatter of the next). At a limit, above all of these: compound 3.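

In this assay, going by these compounds alone, fluoro in place of hydroxy at this site gives an at least 2.8-fold lower number from compound 3 to compound 4 (0.45 log units; beyond the scatter), the first single change here that starts from the 4-hydroxyphenyl group and adds a fluoro group. That size is only a floor, as compound 3 stands at a limit of the assay and not at a number: the limit of > 10000 nM in this assay, at which 1 of the 4 values shown sits. The 4-fluorophenyl group also places the series more finely, since a 1.4-fold lower number from compound 1 to compound 4 (0.16 log units; within the scatter) leaves it level with the 2-methoxyphenyl group, whereas a 2.3-fold higher number from compound 2 to compound 4 (0.37 log units; beyond the scatter) shows that it does not match the 3-chlorophenyl group.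

The compounds shown leave open whether the lower number of compound 4 comes from fluoro itself or simply from the loss of hydroxy, a question that a plain phenyl ring, a 4-methoxyphenyl group or a 4-aminophenyl group at this site could help to settle. They also leave open whether the gap between compound 2 and compound 4 follows from the change of halogen or from where it sits on the ring, which a 4-chlorophenyl or a 3-fluorophenyl group could separate.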